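The compounds below may be only part of what the source reports. "The series", "measured", "known", "first", "only" and "open" are said of these compounds alone.

Working notes on the series, read in a functional assay on NCI-H460 cells (Homo sapiens) for antiproliferative activity; a lower number here means a stronger inhibitor, a higher number a weaker inhibitor. Within the data shown here, compound 1 `COc1ccc(S(=O)(=O)Oc2ccccc2NC(=O)c2ccncc2)cc1` gives 55 nM, the higher of the two numeric values so far. Compound 3 `COc1ccc(S(=O)(=O)Oc2ccccc2NC(=O)c2ccco2)cc1` gives 24 nM. Compound 2 `COc1ccc(S(=O)(=O)Oc2ccccc2NC(=O)c2ccc3ncccc3c2)cc1` reads > 10000 nM, which is a limit and not a number.

Compound 4 `COc1ccc(S(=O)(=O)Oc2ccccc2NC(=O)Oc2ccccc2)cc1` is the next case: phenoxy in place of pyridin-4-yl on a carbonyl carbon. That is phenoxy in place of pyridin-4-yl on a carbonyl carbon, so the amide-type nitrogen stays and an oxygen now stands on the carbonyl carbon.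

Two measured steps at this place bear on the change. The first, a 2.3-fold lower number from compound 1 to compound 3 (0.36 log units; beyond the scatter), is modest, with furan-2-yl entering. The second, an at least 180-fold higher number from compound 1 to compound 2 (2.25 log units; beyond the scatter), is large, with quinolin-6-yl entering. Phenoxy keeps one six-membered aromatic ring, as pyridin-4-yl does, so the modest step is taken as the closer guide, while the large step keeps the upper end of the range wide.

A modest move towards a higher number is expected, with the estimated step being a 2.7-fold higher number from compound 1 to compound 4 (0.44 log units; beyond the scatter). For compound 4 the estimated value is 150 nM, with an expected range from 20 nM to 3000 nM.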

Compound 4, half-maximal inhibitory concentration: > 10000 nM
Compound 4: a limit, no number; the forecaster's own chance of this, stated with the estimate: 15%; middle value at least 66-fold (1.82 log units) away from the limit.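

Compound 4 reads > 10000 nM in this assay and that is a limit, not a number. Phenoxy in place of pyridin-4-yl gives the large step (an at least 180-fold higher number from compound 1 to compound 4 (2.25 log units; beyond the scatter)) and phenoxy in place of furan-2-yl gives another (an at least 410-fold higher number from compound 3 to compound 4 (2.61 log units; beyond the scatter)), so keeping one six-membered aromatic ring on this carbonyl carbon does not by itself keep the potency of compound 1. The step between compound 2 and compound 4 cannot be read, and the series now has two members that give no number: the limit of > 10000 nM in this assay, at which 2 of the 4 values shown sit.

The compounds shown leave open whether the change follows the oxygen on the carbonyl carbon or the carbon-only ring it carries. A plain phenyl or an anilino group on this carbonyl carbon would separate the two.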